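Chloro to Trifluoromethyl on the Pyridine of Compound 3

The source may report more compounds than this note shows. Statements on the series, on what has been measured and on what is new or still open speak of the compounds shown alone.

In a functional assay on HEK293 cells for antagonist activity at Orexin receptor type 2 (Homo sapiens), read by FLIPR and calcium flux (a higher number here means a more potent compound, by a factor of ten per unit of this negative logarithm, a lower number a less potent compound), compound 3 `Cc1nc(C(=O)N2CC3(CC3)C[C@H]2CNc2ccc(Cl)cn2)c(-c2ccccc2)s1` gives 7.1, the second highest of the three numbers measured. Compound 1 `Cc1cccc(NC[C@@H]2CC3(CC3)CN2C(=O)c2nc(C)sc2-c2ccccc2)n1` gives 7.6, and compound 2 `Cc1ccnc(NC[C@@H]2CC3(CC3)CN2C(=O)c2nc(C)sc2-c2ccccc2)n1` gives 7. Among these, a number 0.50 log units lower from compound 1 to compound 3 (beyond the scatter) and a number 0.60 log units lower from compound 1 to compound 2 (beyond the scatter) lie beyond the scatter, whereas a number 0.10 log units higher from compound 2 to compound 3 (within the scatter) does not. Compound 4 `Cc1nc(C(=O)N2CC3(CC3)C[C@H]2CNc2ccc(C(F)(F)F)cn2)c(-c2ccccc2)s1` differs from compound 3 by trifluoromethyl in place of chloro on an aromatic carbon. Going by the values given here, no measured step changes this substituent alone; all three measured steps exchange the whole heteroaryl ring, and each was modest at most. A small step is therefore expected: compound 4 is expected to show a number 0.10 log units higher from compound 3 to compound 4 (within the scatter) in this assay, within the scatter in either direction. The estimated value for compound 4 is 7.2, with a range from 6.6 to 7.8.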

Compound 4, negative logarithm of the antagonist equilibrium constant: 7.7
Compound 4: middle estimate off by 0.50 log units, on the low side; measured number inside the range.
By their numbers in this assay, from the lowest: compounds 2 and 3 (each within the scatter of the next); then compounds 1 and 4 (each within the scatter of the next).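

Exchanging chloro for trifluoromethyl, with the pyridine kept, moves the number by as much as the earlier exchanges of the whole ring did (a number 0.60 log units higher from compound 3 to compound 4 (beyond the scatter)). The 5-(trifluoromethyl)pyridin-2-yl group also stands clear of 4-methylpyrimidin-2-yl (a number 0.70 log units higher from compound 2 to compound 4 (beyond the scatter)), while the comparison with 6-methylpyridin-2-yl (a number 0.10 log units higher from compound 1 to compound 4 (within the scatter)) cannot separate the two. Nothing shown explains this step. Going by these compounds, whether a nitrile, a methoxy group or a bromine at this place would give a similar number remains open. So does whether a fluorine would.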